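Dog liver microsome stability across an aryl change

The source may hold more compounds than are shown below. What is called first, only, known or untested is meant among the compounds shown, and "the series" means these compounds.

Measured so far:
compound 1 `Nc1nc(NCCNc2ncc(-c3ncc[nH]3)c(-c3ccccc3Cl)n2)ccc1[N+](=O)[O-]` gives > 0.5 h in an ADME assay on microsomes from liver (Canis lupus familiaris) for metabolic stability (on this read-out lower numbers stand for a shorter-lived compound and higher numbers for a longer-lived compound), a limit of the assay.
compound 2 `Nc1nc(NCCNc2ncc(-c3ncc[nH]3)c(-c3cc(F)c(Cl)cc3F)n2)ccc1[N+](=O)[O-]` gives > 0.5 h in this assay, likewise a limit.

Compound 1 thus stands only at a limit of this assay, with no number behind it. Among the measured compounds shown here, the one measured step, a step that the two limits leave unreadable from compound 1 to compound 2, cannot be sized, because the limit of > 0.5 h in this assay, at which 2 of the 2 values shown sit, holds both values. Compound 3 `Nc1nc(NCCNc2ncc(-c3ncc[nH]3)c(-c3ccc(Cl)cc3Br)n2)ccc1[N+](=O)[O-]` is not yet measured; it differs from compound 1 by 2-bromo-4-chlorophenyl in place of 2-chlorophenyl on an aromatic carbon. For the measured compounds named here, the only step that bears on this change is the unreadable one from compound 1 to compound 2, so no direction beyond the scatter can be drawn from it. Compound 3 is therefore expected to sit at or beyond the same limit, with an estimated 1 h in this assay, between 0.5 h and 4 h. The expected step is a step that the limit leaves unreadable from compound 1 to compound 3, most likely reported as a limit again.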

Compound 3, half-life: > 0.5 h
Compound 3 gave a limit, no number (the forecaster's own chance of this, stated with the estimate: 80%); the middle value lies beyond the limit too.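

In this assay compound 3 gives > 0.5 h as a limit, not a number. The steps to it from compound 1 and compound 2 cannot be read. The compounds shown leave open how long compound 1, compound 2 and compound 3 actually last in this assay and whether these aryl changes alter that at all.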